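Removal of the pyrrolidinylpropoxy chain on two hydroxamate cores

This account rests on a few compounds, and the source may have more. Where it says the series, first, only, none or still open, it means among the compounds named here.

In an assay on isolated protein for inhibition of protein deacetylase HDAC6 (Homo sapiens), read by fluorescence, with a stated time of 30 min (a lower number here means a stronger inhibitor, a higher number a weaker inhibitor), compound 1 `COc1cc2c(NCc3ccc(C(=O)NO)cc3)cc(-c3ccc(C)o3)nc2cc1OCCCN1CCCC1` gives 11 nM. Compound 3 `COc1cc2nc(-c3ccc(C)o3)cc(NCc3ccc(C(=O)NO)cc3)c2cc1OC` gives 22 nM in this assay; the change from compound 1 is hydrogen in place of 2-(pyrrolidin-1-yl)ethyl on a saturated chain carbon bound to an oxygen on an aromatic ring and the step is a 2.0-fold higher number from compound 1 to compound 3 (0.30 log units; within the scatter). Compound 2 `COc1cc2c(NCC3CCN(c4ncc(C(=O)NO)cn4)CC3)cc(C)nc2cc1OCCCN1CCCC1` gives 350 nM in this assay, a higher number than compound 1 and compound 3, both beyond the scatter. The difference between the core of compound 2 and the core of compound 1 is not broken down here. Compound 4 `COc1cc2nc(C)cc(NCC3CCN(c4ncc(C(=O)NO)cn4)CC3)c2cc1OC` is not yet measured; it differs from compound 2 by hydrogen in place of 2-(pyrrolidin-1-yl)ethyl on a saturated chain carbon bound to an oxygen on an aromatic ring, the same change, at the same place, as from compound 1 to compound 3. The step of a 2.0-fold higher number from compound 2 to compound 4 (0.30 log units; within the scatter) is expected in this assay, resting on the earlier step of a 2.0-fold higher number from compound 1 to compound 3 (0.30 log units; within the scatter). Compound 4 is therefore estimated at 700 nM in this assay, between 300 nM and 1600 nM.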

Compound 4, half-maximal inhibitory concentration: 253 nM
Beside the measured number, compound 4's estimate is 2.8-fold (0.44 log units) above it; measured number below the stated range.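

In this assay, going from 3-(pyrrolidin-1-yl)propoxy to methoxy on the core of compound 2 gives a 1.4-fold lower number from compound 2 to compound 4 (0.14 log units; within the scatter), so the step stays within the scatter on this core, as it does on the core of compound 1. Even so, the step did not carry over unchanged from one core to the other: the same change on two cores in this assay, a 2.0-fold higher number (0.30 log units; within the scatter) from compound 1 to compound 3 and a 1.4-fold lower number (0.14 log units; within the scatter) from compound 2 to compound 4, 2.8-fold (0.44 log units) apart, beyond the scatter of two such steps. With one pair on each core, this does not show which part of the cores goes with the gap, nor how the change would read on any further core.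

Open, as far as these compounds go, is how a morpholine or a dimethylamine in place of the pyrrolidine would read on either core. Also open, from the compounds shown here alone, is how a shorter or longer chain carrying the pyrrolidine would read.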